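Amine tail variants in an antiproliferative series

A few compounds are considered here, and "the series" means these few. Any claim that something is new, unique, unknown or untested is made for them only; others in the source may bear on it.

compound 1 `CN(C)CCCn1c(N)c(-c2nc3ccccc3[nH]2)c2nc(C#N)c(C#N)nc21` — 1230 nM
compound 2 `CCN(CC)CCCn1c(N)c(-c2nc3ccccc3[nH]2)c2nc(C#N)c(C#N)nc21` — 1870 nM
compound 3 `CN(C)CCn1c(N)c(-c2nc3ccccc3n2C)c2nc(C#N)c(C#N)nc21` — 46500 nM

Three compounds are measured in a functional assay on Raji cells (Homo sapiens) for antiproliferative activity, read by MTT assay, with a stated time of 48 h; on this read-out higher numbers stand for weaker inhibition and lower numbers for stronger inhibition. Compound 1 gives 1230 nM, and compound 2, which differs from it by diethylamino in place of dimethylamino on a saturated chain carbon, three bonds along the chain from an aromatic nitrogen, gives 1870 nM. The step is a 1.5-fold higher number from compound 1 to compound 2 (0.18 log units; within the scatter), so on this read-out the two are not told apart.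

Compound 3 is built on a different core; the two have the same atoms joined differently, and the difference between the two cores is not broken down here. In this assay compound 3 gives 46500 nM, a higher number than compound 2 and than compound 1, in both cases beyond the scatter.

Compound 4 `CCN(CC)CCn1c(N)c(-c2nc3ccccc3n2C)c2nc(C#N)c(C#N)nc21` has not yet been measured. It differs from compound 3 by diethylamino in place of dimethylamino on a saturated chain carbon, two bonds along the chain from an aromatic nitrogen. This is the same kind of change as that from compound 1 to compound 2, but not the same one: in the earlier pair the place is three bonds along the chain from an aromatic nitrogen, here it is two bonds along the chain from an aromatic nitrogen, and the core is that of compound 3 rather than compound 1.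

Among the measured compounds shown here, from compound 3 to compound 4 a step of a 1.3-fold higher number from compound 3 to compound 4 (0.11 log units; within the scatter) is expected, because the step of a 1.5-fold higher number from compound 1 to compound 2 (0.18 log units; within the scatter) lay within the scatter and the only difference is the change of place and core. Compound 4 is therefore estimated at 60000 nM in this assay, with a range from 25000 nM to 150000 nM.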

Compound 4, half-maximal inhibitory concentration: 2080 nM
The estimate for compound 4 lay 29-fold (1.46 log units) above the measured number, and the stated range ends above it.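

In this assay, diethylamino in place of dimethylamino on the core of compound 3 gives a 22-fold lower number from compound 3 to compound 4 (1.35 log units; beyond the scatter), so the change is large here and its size does not carry over from the earlier pair: the same change on two cores in this assay, a 1.5-fold higher number (0.18 log units; within the scatter) from compound 1 to compound 2 and a 22-fold lower number (1.35 log units; beyond the scatter) from compound 3 to compound 4, 34-fold (1.53 log units) apart, beyond the scatter of two such steps

In this series, a step read on one of these cores is therefore no guide to the size of the same change on the other. The two pairs do not show where the gap comes from, since they differ in the core and also in the place of the change, three bonds along the chain from an aromatic nitrogen in one pair and two bonds along the chain from an aromatic nitrogen in the other, and no pair shown separates these two differences.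

The compounds shown leave open how the core of compound 1 behaves with a 2-(dimethylamino)ethyl or 2-(diethylamino)ethyl chain, and how the core of compound 3 behaves with the longer chain of compound 1, either of which would help to separate core from place. Also open, going by these compounds, is whether the step on the core of compound 3 extends to other amines on the same chain, such as a pyrrolidine or a morpholine.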